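The source may report more compounds than this note shows. Statements on the series, on what has been measured and on what is new or still open speak of the compounds shown alone.

Compound 1 `O=c1cc(-c2ccccc2)oc2cc(N3COc4ccccc4C3)ccc12`: "not active" (no number reported)
Compound 2 `O=c1cc(-c2ccccc2)oc2ccc(N3COc4c(cccc4[N+](=O)[O-])C3)cc12`: 28400 nM
Compound 3 `O=c1cc(-c2ccccc2)oc2cc(N3COc4c(Cl)cc(Cl)cc4C3)ccc12`: 44500 nM

Three compounds share a core and were tested in a functional assay on MCF7 cells (Homo sapiens) for inhibition, read by MTT assay, with a stated time of 48 h; on this read-out lower numbers stand for stronger inhibition and higher numbers for weaker inhibition. Compound 1 gives "not active" (no number reported) in this assay. Compound 2 gives 28400 nM, the lowest of the two numbers, while compound 3 gives 44500 nM, which lies within the scatter of compound 2. Compound 4 `COc1cccc2c1OCN(c1ccc3oc(-c4ccccc4)cc(=O)c3c1)C2` has not yet been measured. It differs from compound 2 by methoxy in place of nitro on an aromatic carbon. Among the compounds with values here, no measured pair shows a change of this kind, so the data give no direction. The step of a 1.2-fold higher number from compound 2 to compound 4 (0.09 log units; within the scatter) is expected to stay within the scatter. Compound 4 is expected to give 35000 nM, with a range from 12000 nM to 100000 nM.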

Compound 4, half-maximal inhibitory concentration: 17000 nM
The estimate for compound 4 lay 2.1-fold (0.31 log units) above the measured number; the range from low to high includes it.
By their numbers in this assay, from the lowest: compounds 4, 2 and 3 (each within the scatter of the next, the first and the last beyond it).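

In this assay, within the data shown here, methoxy in place of nitro on this aromatic carbon gives a 1.7-fold lower number from compound 2 to compound 4 (0.22 log units; within the scatter) and is the only measured pair with a change at this position. Nitro is thus not needed here for a number to be reported, and the two groups cannot be told apart on this read-out. Nothing available explains this result. On these data alone, whether an amine or a carboxylic acid on the same aromatic carbon would stay within the scatter of compound 2 remains open. So does the outcome for a longer alkoxy chain.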